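Series notes: trifluoromethyl in place of trifluoromethoxy

This account rests on a few compounds, and the source may have more. Where it says the series, first, only, none or still open, it means among the compounds named here.

Measured in a functional assay on Huh-7 cells (Homo sapiens) for inhibition, read by sulforhodamine B assay, with a stated time of 72 h; a higher number here means a weaker inhibitor, a lower number a stronger inhibitor:
compound 1, `COc1ccc2cc(C(C)c3nnc4n3N=C(c3ccc(OC(F)(F)F)cc3)CS4)ccc2c1`, gives 16000 nM
compound 2, `COc1ccc(C2=Nn3c(nnc3C(C)c3ccc(-c4ccccc4)c(F)c3)SC2)cc1`, gives 4300 nM
compound 3, `COc1ccc2cc(C(C)c3n[nH]c(=S)n3N)ccc2c1`, gives 40800 nM

Among these three numbers compound 1 stands second highest. Its nearest neighbour is compound 3, whose number is higher, and the gap lies beyond the scatter of this assay. Furthest from it is compound 2, whose number is lower, again beyond the scatter. Among the measured compounds shown here, no two of the measured compounds differ in only one place, so no single-point step is available for comparison.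

Compound 4, `COc1ccc2cc(C(C)c3nnc4n3N=C(c3ccc(C(F)(F)F)cc3)CS4)ccc2c1`, has not yet been measured. It departs from compound 1 by one change: trifluoromethyl in place of trifluoromethoxy on an aromatic carbon. This is a swap of one small fluorinated group for another at the same place on the shared core. For the measured compounds named here, nothing among the measured compounds shows what this swap does in this assay, so the expectation rests on the change alone: the step of a 1.1-fold lower number from compound 1 to compound 4 (0.06 log units; within the scatter) is expected to be small, with no clear direction, and most likely not beyond the scatter. For compound 4 the estimate is 14000 nM, with a range from 5000 nM to 40000 nM.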

Compound 4, half-maximal inhibitory concentration: 14800 nM
For compound 4 the middle estimate is 1.1-fold (0.02 log units) below the measured one, and the stated range covers the measured number.
By their numbers in this assay, from the lowest: compound 2; then compounds 4 and 1 (each within the scatter of the next); then compound 3.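

In this assay, the swap of 4-(trifluoromethoxy)phenyl to 4-(trifluoromethyl)phenyl gives a 1.1-fold lower number from compound 1 to compound 4 (0.03 log units; within the scatter), the first single-place step available in this series. At this position, on an aromatic carbon para to a large group, removing the oxygen atom and the one hydrogen-bond acceptor counted for trifluoromethoxy therefore leaves compound 1 and compound 4 indistinguishable in this assay. No supporting measurement is available to explain this result.

On these data alone, whether this position accepts groups of a different kind remains open, such as an amine, a carboxylic acid or a longer chain in place of the fluorinated group. Also open, as far as these compounds go, is whether the same swap would stay within the scatter on a core other than that of compound 1.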